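Bromo on the indole ring of a diterpenoid indole ester

This account rests on a few compounds, and the source may have more. Where it says the series, first, only, none or still open, it means among the compounds named here.

Measured compounds:
compound 1 `COC(=O)[C@@]1(C)CCC=C2[C@@H]1CC[C@@H](C)[C@]2(C)Cc1c[nH]c2ccccc12`: 8700 nM
compound 2 `COC(=O)[C@@]1(C)CCC=C2[C@@H]1CC[C@@H](C)[C@]2(C)Cc1c[nH]c2ccc(OC)cc12`: 5700 nM
compound 3 `COC(=O)[C@@]1(C)CCC=C2[C@@H]1CC[C@@H](C)[C@]2(C)Cc1c[nH]c2ccc(C(F)(F)F)cc12`: 18000 nM

All three compounds share one core and differ only in a single group on the aromatic ring. In a functional assay on WiDr cells (Homo sapiens) for inhibition, read by sulforhodamine B assay, with a stated time of 48 h (a higher number here means a weaker inhibitor of growth, a lower number a stronger inhibitor of growth), compound 1 gives 8700 nM. Among the three numbers compound 1 has the second highest; the step of a 1.5-fold lower number from compound 1 to compound 2 (0.18 log units; within the scatter) lies within the scatter, while the step of a 2.1-fold higher number from compound 1 to compound 3 (0.32 log units; beyond the scatter) is a modest weakening.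

Compound 4 `COC(=O)[C@@]1(C)CCC=C2[C@@H]1CC[C@@H](C)[C@]2(C)Cc1c[nH]c2c(Br)cccc12` carries the change (bromo in place of hydrogen on an aromatic carbon). Among the compounds with values here, no measured step places a bromo on the ring, and none changes the position ortho to a fused ring, so the two earlier steps guide only loosely. They show that a methoxy left this assay essentially unchanged and a trifluoromethyl weakened growth inhibition modestly. A bromo is therefore expected to give, at most, a small shift in this assay, most likely none beyond the scatter. The estimated step is a 1.1-fold higher number from compound 1 to compound 4 (0.04 log units; within the scatter). Compound 4 is expected to give about 9500 nM, within a range from 4000 nM to 25000 nM.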

Compound 4, concentration for 50% growth inhibition: 32000 nM
Beside the measured number, compound 4's estimate is 3.4-fold (0.53 log units) below it, and the stated range ends below it.
By their numbers in this assay, from the lowest: compounds 2 and 1 (each within the scatter of the next); then compounds 3 and 4 (each within the scatter of the next).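

In this assay a bromo on the aromatic carbon ortho to a fused ring gives a 3.7-fold higher number from compound 1 to compound 4 (0.57 log units; beyond the scatter) and so shows that a change at this position can weaken growth inhibition beyond the scatter, even though the new group adds only one heavy atom. Within the data shown here, this is the first measured change at this position, and it makes bromo the second group, after the trifluoromethyl of compound 3, to raise the number from that of compound 1, whereas the methoxy of compound 2 stays within the scatter. No measurement here explains why the number rises.

The compounds shown leave open whether this weakening belongs to the bromo or to the position, as no other group sits on this carbon and the bromo sits nowhere else on the ring. A fluoro, a hydroxyl or an amine on this same carbon would help show whether many groups weaken growth inhibition here or only some.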